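The compounds below may be only part of what the source reports. "The series", "measured", "known", "first", "only" and "open" are said of these compounds alone.

In a functional assay on HCT-116 cells (Homo sapiens) for inhibition, read by sulforhodamine B assay, with a stated time of 72 h (on this read-out higher numbers stand for weaker inhibition and lower numbers for stronger inhibition), compound 1 `CC(C)Cc1ccc(C(C)c2nnc3n2N=C(c2ccc(Cl)cc2)CS3)cc1` gives 6700 nM and compound 2 `CC(c1ccc(-c2ccccc2)c(F)c1)c1nnc2n1N=C(c1ccccc1)CS2` gives 9700 nM. Going by the values given here, these two numbers lie within the usual scatter of each other, so compound 1 stands level with the only other measured compound, and neither can be ranked above the other. Compound 3 `CC(C)Cc1ccc(C(C)c2nnc3n2N=C(c2ccc(F)cc2)CS3)cc1` has not yet been measured. It is compound 1 with a single change: fluoro in place of chloro on an aromatic carbon. Put simply, this is fluoro in place of chloro on an aromatic carbon, turning 4-chlorophenyl into 4-fluorophenyl. Among the compounds with values here, no measured pair shows what this swap does on its own. For so small a change, no shift beyond the scatter is expected in this assay, with at most a slight lean towards a higher number. The estimated step of a 1.2-fold higher number from compound 1 to compound 3 (0.08 log units; within the scatter) stays within that scatter. For compound 3 the expected value is 8000 nM, with an estimated range of 3500 nM to 18000 nM.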

Compound 3, half-maximal inhibitory concentration: 12400 nM
For compound 3 the middle estimate is 1.6-fold (0.19 log units) below the measured one; low and high end bracket the measured number.
By their numbers in this assay, from the lowest: compounds 1, 2 and 3 (each within the scatter of the next).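

In this assay, the change from 4-chlorophenyl to 4-fluorophenyl gives a 1.9-fold higher number from compound 1 to compound 3 (0.27 log units; within the scatter), and this pair is the only direct reading of the swap among the compounds shown. Compound 1 and compound 3 differ in this one place alone, so the comparison isolates the halogen on the aromatic carbon, and at this position chloro and fluoro cannot be told apart on this read-out. No measured evidence is available that would explain the result or say what either halogen contributes.

As far as these compounds go, what remains open is whether a clearly different group at this position, such as an amine, a methoxy group or a carboxylic acid, would move the number beyond the scatter. From the compounds shown here alone, it is also open whether the same swap would read the same way if the isobutyl-bearing part of the molecule were changed.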